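Swapping a Fluorophenyl for Ethyl: Solubility Outlook

The source may report more compounds than this note shows. Statements on the series, on what has been measured and on what is new or still open speak of the compounds shown alone.

Measured so far in a physicochemical assay for solubility, read by HPLC; a lower number here means a less soluble compound, a higher number a more soluble compound:
- compound 1, `O=C(CC1CCCCC1)N1CCN(c2nc(=O)c3cc(C(F)(F)F)cc([N+](=O)[O-])c3s2)CC1`, gives 0.12 ug/mL
- compound 2, `O=C(c1cccc(F)c1)N1CCN(c2nc(=O)c3cc(C(F)(F)F)cc([N+](=O)[O-])c3s2)CC1`, gives 0.2 ug/mL
- compound 3, `O=C(c1ccc(F)cc1)N1CCN(c2nc(=O)c3cc(C(F)(F)F)cc([N+](=O)[O-])c3s2)CC1`, gives 1.69 ug/mL

Compound 3 stands highest of the three in this assay. Its nearest neighbour is compound 2, reached by an 8.5-fold higher number from compound 2 to compound 3 (0.93 log units; beyond the scatter), and the furthest is compound 1, reached by a 14-fold higher number from compound 1 to compound 3 (1.15 log units; beyond the scatter). Compound 1 and compound 2 sit close together, as a 1.7-fold higher number from compound 1 to compound 2 (0.22 log units; within the scatter) shows.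

Compound 4, `CCC(=O)N1CCN(c2nc(=O)c3cc(C(F)(F)F)cc([N+](=O)[O-])c3s2)CC1`, differs from compound 3 in one place: ethyl in place of 4-fluorophenyl on a carbonyl carbon. For the measured compounds named here, no measured step swaps an aromatic group for a short chain, so the three steps bear on it only loosely. Going by the values given here, they show that the identity of the group on the carbonyl carbon can move this assay a good deal, and that compound 1, the one compound without an aromatic group there, gives the lowest number. The direction for compound 4 is therefore uncertain, and a drop below compound 3, or no step beyond the scatter, is expected: a 1.1-fold lower number from compound 3 to compound 4 (0.05 log units; within the scatter). Compound 4 is estimated at 1.5 ug/mL, within 0.3 ug/mL to 8 ug/mL.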

Compound 4, solubility: 3.29 ug/mL
Compound 4: middle estimate off by 2.2-fold (0.34 log units), on the low side; low and high end bracket the measured number.
By their numbers in this assay, from the lowest: compounds 1 and 2 (each within the scatter of the next); then compounds 3 and 4 (each within the scatter of the next).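

Ethyl on the carbonyl carbon cannot be told apart from 4-fluorophenyl in this assay, with a 1.9-fold higher number from compound 3 to compound 4 (0.29 log units; within the scatter), so an aromatic ring at this position is not needed for a number in the upper pair. Ethyl also stands well clear of 3-fluorophenyl, with a 16-fold higher number from compound 2 to compound 4 (1.22 log units; beyond the scatter), and methyl in place of cyclohexyl on the saturated chain carbon gives a 27-fold higher number from compound 1 to compound 4 (1.44 log units; beyond the scatter), so the lack of an aromatic ring does not by itself go with a low number, as compound 1 and compound 4 both lack one. Nothing shown here accounts for these differences.

Open, from the compounds shown here alone, is how a longer chain such as butyl, or a bare methyl, would compare with ethyl at this position. Also open, going by these compounds, is how a chain carrying an amine or a carboxylic acid would read.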